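Extending the alkoxy chain: from propyl to butyl

The source may report more compounds than this note shows. Statements on the series, on what has been measured and on what is new or still open speak of the compounds shown alone.

Measured compounds:
Compound 1 `COc1cccc(C(=O)Nc2cccc(C(=O)O)c2)c1` — 1040 nM
Compound 2 `CCOc1cccc(C(=O)Nc2cccc(C(=O)O)c2)c1` — 2350 nM
Compound 3 `CCCOc1cccc(C(=O)Nc2cccc(C(=O)O)c2)c1` — 2150 nM

All three share one core and differ only in the chain that sits on the aromatic oxygen. In an assay on isolated protein for agonist activity at Bile acid receptor (Homo sapiens), read by TR-FRET, with a stated time of 3 h, in the absence of a further agent (a lower number here means that less compound is needed, a higher number that more compound is needed for the effect), compound 3 gives 2150 nM, the second highest of the three numbers; it sits within the scatter of compound 2 and is separated from compound 1 by a 2.1-fold higher number from compound 1 to compound 3 (0.32 log units; beyond the scatter).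

Compound 4 `CCCCOc1cccc(C(=O)Nc2cccc(C(=O)O)c2)c1` is not yet measured. Its change from compound 3 is methyl in place of hydrogen on a saturated chain carbon, three bonds along the chain from an oxygen on an aromatic ring, which at the level of the whole group reads as propyl to butyl.

For the measured compounds named here, two measured steps bear on this. The first lengthening, a 2.3-fold higher number from compound 1 to compound 2 (0.35 log units; beyond the scatter), raised the number. Going by the values given here, the next, a 1.1-fold lower number from compound 2 to compound 3 (0.04 log units; within the scatter), stayed within the scatter, so adding to the chain beyond the first carbon has not shifted the number so far. The step from compound 3 to compound 4 is therefore expected to be small as well, a 1.1-fold higher number from compound 3 to compound 4 (0.03 log units; within the scatter), with no direction beyond the scatter. Compound 4 is estimated at 2300 nM, within 1100 nM to 4800 nM.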

Compound 4, half-maximal effective concentration: 3150 nM
Estimate against measurement, compound 4: 1.4-fold (0.14 log units) below; measured number inside the range.
By their numbers in this assay, from the lowest: compound 1; then compounds 3, 2 and 4 (each within the scatter of the next).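

In this assay, extending the chain three bonds along from the oxygen on the aromatic ring still does not move the number beyond the scatter, a 1.5-fold higher number from compound 3 to compound 4 (0.17 log units; within the scatter), and neither does placing ethyl two bonds along, a 1.3-fold higher number from compound 2 to compound 4 (0.13 log units; within the scatter). Only against the methyl chain does butyl stand clearly apart, a 3.0-fold higher number from compound 1 to compound 4 (0.48 log units; beyond the scatter), so the ethyl, propyl and butyl chains cannot be told apart, and every step beyond the scatter starts from methyl. The same change made at different places along the chain gives steps that agree within the scatter, so these compounds show no clear difference between changing the first carbon and changing one further out: the same change on two cores in this assay, a 2.3-fold higher number (0.35 log units; beyond the scatter) from compound 1 to compound 2 and a 1.5-fold higher number (0.17 log units; within the scatter) from compound 3 to compound 4, 1.5-fold (0.19 log units) apart, within the scatter of two such steps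

On these data alone, whether a longer chain such as hexyl would stay level with these numbers remains open. So does the effect of an amine or a hydroxyl group at the end of the chain.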